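The compounds below may be only part of what the source reports. "The series", "measured", "known", "first", "only" and "open" are said of these compounds alone.

Compound 3 `CC#CC(CC(=O)O)c1ccc(OCc2ccn3cc(-c4cccc(C)c4)nc3c2)cc1` gives the highest of the three numbers in an assay on isolated protein for agonist activity at Free fatty acid receptor 1 (Homo sapiens); on this read-out lower numbers stand for an effect already at smaller amounts and higher numbers for an effect only at larger amounts of compound: compound 3 gives 1510 nM, while compound 1 `CC#CC(CC(=O)O)c1ccc(OCc2ccc3nc(-c4ccc(OC)cc4)cn3c2)cc1` gives 47 nM and compound 2 `CC#CC(CC(=O)O)c1ccc(OCc2ccc3nc(-c4ccc(C5CCCCC5)cc4)cn3c2)cc1` gives 417 nM. Compound 4 `CC#CC(CC(=O)O)c1ccc(OCc2ccn3cc(-c4ccccc4)nc3c2)cc1` differs from compound 3 by a single change, (hydrogen in place of methyl on an aromatic carbon). Among the measured compounds shown here, the only measured step that differs in one place, an 8.9-fold higher number from compound 1 to compound 2 (0.95 log units; beyond the scatter), concerns a different group on a different part of the molecule and is a much larger change, so it bears only loosely on this one. Since the change here is small, the step is expected to stay within the scatter. For compound 4 the estimate in this assay is 1200 nM, with a range of 450 nM to 3200 nM, meaning an expected step of a 1.3-fold lower number from compound 3 to compound 4 (0.10 log units; within the scatter).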

Compound 4, half-maximal effective concentration: 1260 nM
The estimate for compound 4 lay 1.1-fold (0.02 log units) below the measured number; the measured number falls inside the stated range.
By their numbers in this assay, from the lowest: compound 1; then compound 2; then compounds 4 and 3 (each within the scatter of the next).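

In this assay, replacing the methyl of the 3-methylphenyl group with hydrogen gives no step beyond the scatter (a 1.2-fold lower number from compound 3 to compound 4 (0.08 log units; within the scatter)). Among the compounds shown here, on this aromatic carbon, meta to a large group, the methyl therefore makes no readable difference between these two compounds, something the earlier compounds could not show. The compounds shown leave open whether another group at this place, such as an amine, a chlorine or a longer chain, would shift the number beyond the scatter. No measurement offered here accounts for this result.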